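The source may hold more compounds than are shown below. What is called first, only, known or untested is meant among the compounds shown, and "the series" means these compounds.

Measured compounds:
- compound 1, `N[C@H]1CC[C@H](Nc2c(C(=O)NCc3ccc(F)cc3)nc(N3CCCCS3(=O)=O)c3cccnc23)CC1`, in a functional assay on SK-BR-3 cells (Homo sapiens) for cytotoxicity, read by MTT assay, with a stated time of 72 h (on this read-out lower numbers stand for stronger inhibition and higher numbers for weaker inhibition), gives 8500 nM
- compound 2, `N[C@H]1CC[C@H](Nc2c(C(=O)NCc3ccco3)nc(Br)c3cccnc23)CC1`, in this assay gives 10000 nM

Of the two numbers, compound 2 has the higher one, but its value and that of compound 1 lie within the scatter of each other, so neither can be called the weaker. Compound 3, `N[C@H]1CC[C@H](Nc2c(C(=O)Nc3ccccc3)nc(Br)c3cccnc23)CC1`, has not been measured yet. It differs from compound 2 only in one place: phenyl in place of (furan-2-yl)methyl on an amide-type nitrogen. Going by the values given here, with no measured pair showing what such a change does here, the expectation for compound 3 in this assay is a step no larger than the scatter, no change at the digits printed from compound 2 to compound 3 (within the scatter). Compound 3 is therefore estimated at 10000 nM, within a range from 4000 nM to 25000 nM.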

Compound 3, half-maximal inhibitory concentration: 2000 nM
Beside the measured number, compound 3's estimate is 5.0-fold (0.70 log units) above it; measured number below the stated range.
By their numbers in this assay, from the lowest: compound 3; then compounds 1 and 2 (each within the scatter of the next).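

Phenyl in place of (furan-2-yl)methyl on the amide-type nitrogen gives a 5.0-fold lower number from compound 2 to compound 3 (0.70 log units; beyond the scatter) in this assay. Going by these compounds alone, this is the first sign that the group at this position can shift the result by more than the scatter, with stronger inhibition for the phenyl amide. Nothing available explains this shift. Going by these compounds, the change swaps the ring and also removes the methyl link, so the role of each remains open. A benzyl group on the same nitrogen would separate the two, and a chlorophenyl group would show whether the phenyl ring tolerates added atoms.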